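Aryl Substituent Change and Protein Kinase C Iota Inhibition

The compounds below may be only part of what the source reports. "The series", "measured", "known", "first", "only" and "open" are said of these compounds alone.

Compound 1 `CC(C)(C)C1=NN(c2cccc(Cl)c2)C(c2ccc(O)cc2)C1`: 43.5%
Compound 2 `CC(C)(C)C1=NN(c2cccc(F)c2)C(c2ccc(O)cc2)C1`: 19.3%
Compound 3 `Cc1cccc(N2N=C(C(C)(C)C)CC2c2ccc(O)cc2)c1`: 13.9%

Among the measured compounds shown here, in an assay on isolated protein for inhibition of protein kinase C iota type (Homo sapiens), tested at 20 uM (on this read-out lower numbers stand for less inhibition and higher numbers for more inhibition at the one concentration tested (going by the name of the read-out)), compound 3 gives 13.9%, the smallest of the three numbers; the step of a number 5.4 percentage points lower from compound 2 to compound 3 (within the scatter) lies within the scatter, while the step of a number 29.6 percentage points lower from compound 1 to compound 3 (beyond the scatter) is the only one of its steps beyond the scatter. Compound 4 `CC(C)(C)C1=NN(c2ccc(F)c(Cl)c2)C(c2ccc(O)cc2)C1` carries 3-chloro-4-fluorophenyl in place of 3-methylphenyl on an amine nitrogen in a ring. For the measured compounds named here, the step of a number 29.6 percentage points lower from compound 1 to compound 3 (beyond the scatter) bears most directly on this change, since it returns chloro where methyl stands; the added fluorine has no measured counterpart here, as the step of a number 24.2 percentage points lower from compound 1 to compound 2 (beyond the scatter) concerns fluoro in place of chloro. A rise back toward compound 1 is therefore expected, with wide uncertainty. Compound 4 is estimated at 40%, between 20% and 60%, meaning an expected step of a number 26.1 percentage points higher from compound 3 to compound 4 (beyond the scatter).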

Compound 4, a percentage reported as inhibition, at one concentration (the size of the read-out at that concentration, not a potency): 31.6%
The estimate for compound 4 lay 8.4 percentage points above the measured number; the measured number falls inside the stated range.
By their numbers in this assay, from the lowest: compounds 3 and 2 (each within the scatter of the next); then compound 4; then compound 1.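

Placing fluoro on an aromatic carbon of compound 1 lowers the number (a number 11.9 percentage points lower from compound 1 to compound 4 (beyond the scatter)), so a change at a second carbon of this aryl group moves the read-out beyond the scatter. The 3-chloro-4-fluorophenyl group still stands above 3-methylphenyl (a number 17.7 percentage points higher from compound 3 to compound 4 (beyond the scatter)) and 3-fluorophenyl (a number 12.3 percentage points higher from compound 2 to compound 4 (beyond the scatter)), leaving the chloro-bearing compounds 1 and 4 above compounds 2 and 3. Nothing measured here explains these steps.

Going by these compounds, whether a methoxy group or an amine on this aryl ring would match compound 1 stays open.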